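The compounds below may be only part of what the source reports. "The series", "measured", "known", "first", "only" and "open" are said of these compounds alone.

Compound 1 `Cc1cccc(/C(N)=N/NC(=S)N2CCOCC2)n1` is tested in a functional assay on HeLa cells (Homo sapiens) for cytotoxicity, read by MTT assay, with a stated time of 72 h, tested at 30 uM (on this read-out higher numbers stand for more inhibition of growth at the one concentration tested and lower numbers for less inhibition of growth), where compound 1 gives 86.9%. Compound 2 `Cc1cccc(/C(N)=N/NC(=S)N2CCCCC2)n1` differs from it only at the ring attached to the thiocarbonyl carbon, and in this assay compound 2 gives 83.5%. Among the compounds with values here, the step of a number 3.4 percentage points lower from compound 1 to compound 2 (within the scatter) is within the scatter, so the two measured numbers cannot be told apart; compound 2 stands level with compound 1, with no other compound measured.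

Compound 3 `Cc1cccc(/C(N)=N/NC(=S)N2CCCC2)n1` is not yet measured. It is obtained from compound 2 by the change (pyrrolidin-1-yl in place of piperidin-1-yl on a thiocarbonyl carbon). Within the data shown here, the only step that bears on this change is the ring exchange on the same thiocarbonyl carbon, a number 3.4 percentage points lower from compound 1 to compound 2 (within the scatter), which was small. One ring of this kind has already been swapped for another without moving the read-out beyond the scatter, so for compound 3 a step of about a number 1.5 percentage points lower from compound 2 to compound 3 (within the scatter) in this assay is expected, that is no change beyond the scatter. Compound 3 is therefore estimated at 82%, with a range from 68% to 92%.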

Compound 3, percent growth inhibition at one concentration: 74.5%
For compound 3 the middle estimate is 7.5 percentage points above the measured one; measured number inside the range.
By their numbers in this assay, from the lowest: compounds 3, 2 and 1 (each within the scatter of the next, the first and the last beyond it).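

In this assay, within the data shown here, a ring exchange on the thiocarbonyl carbon now gives a step beyond the scatter for the first time, with a number 12.4 percentage points lower from compound 1 to compound 3 (beyond the scatter), while a number 9 percentage points lower from compound 2 to compound 3 (within the scatter) stays inside it. This position is therefore not wholly indifferent to the ring it carries, yet the three compounds do not split cleanly by ring size, as compound 2, with its six-membered ring, lies within the scatter of both compound 1 and compound 3. Nothing available gives a reason for this difference.

Going by these compounds, it remains open whether an open-chain dimethylamino group, a seven-membered azepan-1-yl ring or a piperazin-1-yl ring with a free amine would hold the read-out or move it further. On these data alone, it is also open whether the same ring exchanges would give similar steps with other groups on the shared core.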